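A few compounds are considered here, and "the series" means these few. Any claim that something is new, unique, unknown or untested is made for them only; others in the source may bear on it.

Measured in a functional assay on HepG2 cells (Homo sapiens) for antiproliferative activity, read by MTT assay, with a stated time of 48 h; a lower number here means a stronger inhibitor, a higher number a weaker inhibitor:
- compound 1 `COc1ccc(N(C)c2ccnc(Cl)n2)cc1`: 2120 nM
- compound 2 `COc1ccc(N(C)c2ccnc(Cl)n2)cc1O`: 464 nM
- compound 3 `COc1ccc(N(C)c2ccnc(Cl)n2)cc1OCCCCBr`: 168 nM

Compound 3 has the lowest number of the three, with a 2.8-fold lower number from compound 2 to compound 3 (0.44 log units; beyond the scatter). Compound 4 `COc1ccc(N(C)c2ccnc(Cl)n2)cc1OCCCCCBr` departs from it by a single change: bromomethyl in place of bromo on a saturated chain carbon, four bonds along the chain from an oxygen on an aromatic ring, with bromomethyl in place of bromo on a saturated chain carbon, four bonds along the chain from an oxygen on an aromatic ring.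

For the measured compounds named here, no measured pair differs in chain length alone, so the evidence is indirect. The steps that come closest are those that introduced the whole 4-bromobutyl group, a modest one in a 2.8-fold lower number from compound 2 to compound 3 (0.44 log units; beyond the scatter) and a large one in a 13-fold lower number from compound 1 to compound 3 (1.10 log units; beyond the scatter). The hydroxy step, a 4.6-fold lower number from compound 1 to compound 2 (0.66 log units; beyond the scatter), says less about the chain. The present change is much smaller than either chain step, so no shift beyond the scatter is expected in this assay. The expected result is a 1.1-fold lower number from compound 3 to compound 4 (0.05 log units; within the scatter). For compound 4 the estimate is 150 nM, with an expected range from 70 nM to 340 nM.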

Compound 4, half-maximal inhibitory concentration: > 10000 nM
Compound 4: only a limit was reported (the forecaster's own chance of this, stated with the estimate: 2%); middle value at least 66-fold (1.82 log units) from the limit.
By their numbers in this assay, from the lowest: compound 3; then compound 2; then compound 1. At a limit, above all of these: compound 4.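

In this assay compound 4 is recorded only as a limit of the assay, not as a number: the limit of > 10000 nM in this assay, at which 1 of the 4 values shown sits.

Even so, this position proves far more sensitive than the earlier compounds suggested: bromomethyl in place of bromo on a saturated chain carbon, four bonds along the chain from an oxygen on an aromatic ring, gives an at least 59-fold higher number from compound 3 to compound 4 (1.77 log units; beyond the scatter). The 5-bromopentyl group also places compound 4 behind both compounds that lack a chain, with an at least 21-fold higher number from compound 2 to compound 4 (1.33 log units; beyond the scatter) and an at least 4.7-fold higher number from compound 1 to compound 4 (0.67 log units; beyond the scatter), whereas the 4-bromobutyl group had lowered the number from both.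

The compounds shown leave open how activity changes along the series, since a 3-bromopropyl chain and any longer chain are absent from them. They also leave open whether the bromo end matters, which an amine or a carboxylic acid at the same chain end could address.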